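The source may report more compounds than this note shows. Statements on the series, on what has been measured and on what is new or still open speak of the compounds shown alone.

Compound 1 `CNC(=O)[C@@]12C[C@@H]1[C@@H](n1cnc3c(NC)nc(C#Cc4ccccc4OC)nc31)[C@H](O)[C@@H]2O` is the starting point. In an assay on CHO cells for displacement of a labelled ligand from adenosine receptor A1 (Homo sapiens), read by scintillation counting, with a stated time of 60 min, tested at 10 uM (a lower number here means less inhibition, a higher number more inhibition at the concentration tested (going by the name of the read-out)), compound 1 gives 12%, the lowest of the three numbers measured. Compound 2 `CCc1ccc(C#Cc2nc(NC)c3ncn([C@H]4[C@H](O)[C@H](O)[C@]5(C(=O)NC)C[C@H]45)c3n2)o1` gives 18%, and the step of a number 6 percentage points higher from compound 1 to compound 2 (within the scatter). Compound 3 `CNC(=O)[C@@]12C[C@@H]1[C@@H](n1cnc3c(NC)nc(C#CC4CC4)nc31)[C@H](O)[C@@H]2O` gives 38%, and the step of a number 26 percentage points higher from compound 1 to compound 3 (beyond the scatter).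

Compound 4 `CNC(=O)[C@@]12C[C@@H]1[C@@H](n1cnc3c(NC)nc(C#CC4CCCCC4)nc31)[C@H](O)[C@@H]2O` differs from compound 1 in one place: cyclohexyl in place of 2-methoxyphenyl on a triple-bonded carbon. The step to compound 3 bears most on this, since it also replaces the 2-methoxyphenyl with a non-aromatic carbon ring and was modest but beyond the scatter; the step to compound 2 stayed within the scatter. A modest rise is therefore expected, as the step of a number 22 percentage points higher from compound 1 to compound 4 (beyond the scatter). Compound 4 is expected to give 34%, in the range 14% to 54%.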

Compound 4, a percentage reported as inhibition, at one concentration (the size of the read-out at that concentration, not a potency): 15%
Beside the measured number, compound 4's estimate is 19 percentage points above it; measured number inside the range.
By their numbers in this assay, from the lowest: compounds 1, 4 and 2 (each within the scatter of the next); then compound 3.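

In this assay the step of a number 3 percentage points higher from compound 1 to compound 4 (within the scatter) and the step of a number 3 percentage points lower from compound 2 to compound 4 (within the scatter) show that a non-aromatic carbon ring on the triple-bonded carbon does not by itself separate a compound from those carrying aromatic rings. The step of a number 23 percentage points lower from compound 3 to compound 4 (beyond the scatter) shows that cyclopropyl and cyclohexyl, both such rings, do not behave alike at this position. Nothing measured here explains that difference. On these data alone, whether cyclobutyl or cyclopentyl rings fall nearer cyclopropyl or cyclohexyl remains open. So does the effect of an open chain such as propyl, or of an amine at the end of one.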